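The compounds below may be only part of what the source reports. "The series", "measured", "known", "first", "only" and "open" are said of these compounds alone.

Measured so far:
- compound 1, `CC1=C(/C=C/C(=O)/C=C/c2ccccc2)C(C)(C)CCC1O`: 8000 nM
- compound 2, `CC1=C(/C=C/C(=O)/C=C/c2ccccc2C(F)(F)F)C(C)(C)CCC1O`: 2300 nM
- compound 3, `CC1=C(/C=C/C(=O)/C=C/c2cc(C(F)(F)F)ccc2C(F)(F)F)C(C)(C)CCC1O`: "not determined" (no result reported)

In a functional assay on CWR22R cells (Homo sapiens) for cytotoxicity, read by MTT assay, with a stated time of 72 h (a lower number here means a stronger inhibitor, a higher number a weaker inhibitor), compound 2 gives the lowest of the two numbers available. Its nearest neighbour is compound 1, and the step of a 3.5-fold lower number from compound 1 to compound 2 (0.54 log units; beyond the scatter) separates them. Compound 3 has no value in this assay. Compound 4, `CC1=C(/C=C/C(=O)/C=C/c2ccccc2F)C(C)(C)CCC1O`, has not been measured. It differs from compound 2 by fluoro in place of trifluoromethyl on an aromatic carbon: the trifluoromethyl carried by compound 2 is replaced by fluoro on an aromatic carbon. Going by the values given here, the only measured step that bears on this change is the one in which the trifluoromethyl entered, a 3.5-fold lower number from compound 1 to compound 2 (0.54 log units; beyond the scatter), a modest step. Taking most of that group away again, while keeping a single fluorine, is expected to undo part of that step, so the number for compound 4 is expected to fall between those of compound 1 and compound 2. This change is therefore expected to give a 1.7-fold higher number from compound 2 to compound 4 (0.24 log units; within the scatter). Compound 4 is expected to give 4000 nM in this assay, with a range from 1500 nM to 12000 nM.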

Compound 4, half-maximal inhibitory concentration: 3300 nM
Compound 4: the middle estimate sits 1.2-fold (0.08 log units) above what was measured, within the range that was stated.
By their numbers in this assay, from the lowest: compounds 2 and 4 (each within the scatter of the next); then compound 1.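

In this assay, the new result shows that the gain at this position, on an aromatic carbon ortho to a large group, does not depend on trifluoromethyl: fluoro in place of hydrogen also gives a modest step beyond the scatter, a 2.4-fold lower number from compound 1 to compound 4 (0.38 log units; beyond the scatter). Exchanging trifluoromethyl for fluoro gives a 1.4-fold higher number from compound 2 to compound 4 (0.16 log units; within the scatter), which lies within the scatter, so compound 2 and compound 4 cannot be told apart here, and in these compounds the larger group brings no clear advantage over the single fluorine. Nothing available explains why either group gives the step from the unsubstituted compound 1.

Going by these compounds, whether a non-fluorinated group at this position, such as chloro, methoxy or an amine, would give a similar step remains open. Compound 3 has no value, so the effect of adding a second trifluoromethyl to the ring cannot be read.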